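This account rests on a few compounds, and the source may have more. Where it says the series, first, only, none or still open, it means among the compounds named here.

Measured so far in a functional assay on A549 cells (Homo sapiens) for cytotoxicity, read by MTT assay, with a stated time of 48 h (on this read-out lower numbers stand for stronger inhibition and higher numbers for weaker inhibition), are these compounds:
compound 1 (`COc1c(OCc2cnoc2C)cc(O)c2c(=O)cc(-c3ccccc3)oc12`) gives > 100000 nM as a limit of the assay, not a number
compound 2 (`COc1c(OCCCCNCc2ccccc2)cc(O)c2c(=O)cc(-c3ccccc3)oc12`) gives 4590 nM as a measured number
compound 3 (`CCN(CC)CCCOc1cc(O)c2c(=O)cc(-c3ccccc3)oc2c1OC`) gives 1830 nM as a measured number

Compound 3 has the lower of the two exact numbers. The gap to the other is the modest one (a 2.5-fold lower number from compound 2 to compound 3 (0.40 log units; beyond the scatter)).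

Compound 4 (`CCN(CC)CCCCOc1cc(O)c2c(=O)cc(-c3ccccc3)oc2c1OC`) differs from compound 3 by one change ((diethylamino)methyl in place of diethylamino on a saturated chain carbon, three bonds along the chain from an oxygen on an aromatic ring), which reads as 3-(diethylamino)propyl to 4-(diethylamino)butyl. Among the compounds with values here, no measured step makes this change alone. The closest is that same modest step, with diethylamino in place of (benzylamino)methyl at the same place on the chain. The two large steps (an at least 21-fold lower number from compound 1 to compound 2 (1.33 log units; beyond the scatter) and an at least 54-fold lower number from compound 1 to compound 3 (1.73 log units; beyond the scatter)) replace 5-methyl-1,2-oxazol-4-yl and start from a limit. They set no size for the present change.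

A small step toward a higher number is therefore expected, no larger than the modest one (a 2.5-fold lower number from compound 2 to compound 3 (0.40 log units; beyond the scatter)). The expected step (a 1.4-fold higher number from compound 3 to compound 4 (0.14 log units; within the scatter)) may stay within the scatter. For compound 4 the estimated value is 2500 nM with an expected range (1000 nM to 6000 nM).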

Compound 4, half-maximal inhibitory concentration: 1000 nM
Compound 4: middle estimate off by 2.5-fold (0.40 log units), on the high side; the range from low to high includes it.
By their numbers in this assay, from the lowest: compounds 4 and 3 (each within the scatter of the next); then compound 2. At a limit, above all of these: compound 1.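

In this assay, going from 3-(diethylamino)propyl to 4-(diethylamino)butyl gives a 1.8-fold lower number from compound 3 to compound 4 (0.26 log units; within the scatter), so this extension of the chain does not separate the two compounds. With the chain length held, diethylamino in place of benzylamino gives a 4.6-fold lower number from compound 2 to compound 4 (0.66 log units; beyond the scatter); this reads the change at the chain end alone, whereas the earlier step between compound 2 and compound 3 also changed the chain length. Compound 1 stands at a limit of the assay, so an at least 100-fold lower number from compound 1 to compound 4 (2.00 log units; beyond the scatter) is a bound and not a size: the limit of > 100000 nM in this assay, at which 1 of the 4 values shown sits.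

Still open, on these data alone, is whether a shorter chain, 2-(diethylamino)ethyl, or a longer one, 5-(diethylamino)pentyl, would stay level with compound 3 and compound 4. Also open, as far as these compounds go, is how a cyclic amine such as piperidine or morpholine would compare with diethylamino at the chain end.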